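Two Limits and an Untested Replacement

This account rests on a few compounds, and the source may have more. Where it says the series, first, only, none or still open, it means among the compounds named here.

Measured in a functional assay on HeLa cells (Homo sapiens) for inhibition, read by CCK-8 assay, with a stated time of 48 h; on this read-out higher numbers stand for weaker inhibition and lower numbers for stronger inhibition:
- compound 1 `COc1cccc(NC(=O)NCCNS(=O)(=O)c2ccc(-c3ccccc3OCc3ccccc3)s2)c1`: > 50000 nM
- compound 2 `Cc1cc(C)cc(NC(=O)NCCNS(=O)(=O)c2ccc(-c3ccccc3OCc3ccccc3)s2)c1`: > 50000 nM

Both entries are limits of the assay, not numbers. Compound 2 therefore has no exact position on the scale, and it shares its place with compound 1: the limit of > 50000 nM in this assay, at which 2 of the 2 values shown sit.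

Compound 3 `O=S(=O)(NCCNC(=S)Nc1ccc(Cl)cc1)c1ccc(-c2ccccc2OCc2ccccc2)s1` differs from compound 2 on an amine nitrogen, where the (3,5-dimethylphenyl)carbamoyl group is replaced: a group of 10 heavy atoms (7 carbon, 1 nitrogen, 1 sulfur, 1 chlorine; one six-membered aromatic ring of carbon only) in place of a group of 11 heavy atoms (9 carbon, 1 nitrogen, 1 oxygen; one six-membered aromatic ring of carbon only), on an amine nitrogen.

For the measured compounds named here, the only measured step is a step that the two limits leave unreadable from compound 1 to compound 2. It offers no size to carry forward, so no step beyond the scatter, in either direction, can be expected in this assay. Compound 3 will most likely also report only a limit, though a measurable value remains possible. The expected step is an at least 1.1-fold lower number from compound 2 to compound 3 (0.04 log units; that floor lies within the scatter). The estimated value for compound 3 is 45000 nM, with an expected range of 12000 nM to 100000 nM.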

Compound 3, half-maximal inhibitory concentration: 7000 nM
Estimate against measurement, compound 3: 6.4-fold (0.81 log units) above; the measured number lies below the stated range.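

Replacing the (3,5-dimethylphenyl)carbamoyl group on the amine nitrogen with the group of compound 3, which carries sulfur and chlorine, gives an at least 7.1-fold lower number from compound 2 to compound 3 (0.85 log units; beyond the scatter) in this assay. The same group set against the group of compound 1 gives an at least 7.1-fold lower number from compound 1 to compound 3 (0.85 log units; beyond the scatter), so a change at this place can bring the read-out to a measurable number, which the earlier pair could not show. Both steps are only minimum sizes, since compound 1 and compound 2 remain limits of the assay and not numbers: the limit of > 50000 nM in this assay, at which 2 of the 3 values shown sit.

The entering group brings in sulfur and chlorine together, so the compounds shown cannot say which of the two atoms goes with the stronger inhibition. They also leave open how a bromine atom or a nitrile in place of the chlorine would read.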